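A few compounds are considered here, and "the series" means these few. Any claim that something is new, unique, unknown or untested is made for them only; others in the source may bear on it.

In a functional assay on MCF7 cells (Homo sapiens) for antiproliferative activity, read by sulforhodamine B assay, with a stated time of 48 h (on this read-out lower numbers stand for stronger inhibition and higher numbers for weaker inhibition), three compounds sharing one core have been measured. Compound 1 `CCCN1CCN(c2ccc(S(=O)(=O)Oc3c(Cl)cc(Cl)cc3Cl)cc2)C1=O` gives > 100000 nM, which is a limit of the assay. Compound 2 `CCCN1CCN(c2ccc(S(=O)(=O)Oc3cccc(F)c3)cc2)C1=O` gives 24000 nM, and compound 3 `CCCN1CCN(c2ccc(S(=O)(=O)Oc3ccc(OC)cc3)cc2)C1=O` gives 20000 nM. Compound 3 stands level with compound 2, since a 1.2-fold lower number from compound 2 to compound 3 (0.08 log units; within the scatter) lies within the scatter.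

Compound 4 `CCCN1CCN(c2ccc(S(=O)(=O)Oc3ccc(Cl)cc3)cc2)C1=O` keeps the core of compound 3 and changes one group: chloro in place of methoxy on an aromatic carbon. Chloro takes the place of methoxy on an aromatic carbon, para to a large group, turning 4-methoxyphenyl into 4-chlorophenyl.

The closest guide is the change of this same aryl group from compound 2, where a 1.2-fold lower number from compound 2 to compound 3 (0.08 log units; within the scatter) stayed within the scatter. Compound 1 also carries chlorine, but its aryl group differs further, so an at least 4.1-fold lower number from compound 1 to compound 2 (0.61 log units; beyond the scatter) and an at least 5.0-fold lower number from compound 1 to compound 3 (0.69 log units; beyond the scatter) offer only a weak warning of a possible rise.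

The expected change in this assay is therefore none beyond the scatter, with an estimated 1.3-fold higher number from compound 3 to compound 4 (0.10 log units; within the scatter). For compound 4 the estimated value is 25000 nM, expected to fall between 10000 nM and 65000 nM.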

Compound 4, half-maximal inhibitory concentration: 18000 nM
Compound 4: middle estimate off by 1.4-fold (0.14 log units), on the high side; the range from low to high includes it.
By their numbers in this assay, from the lowest: compounds 4, 3 and 2 (each within the scatter of the next). At a limit, above all of these: compound 1.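

In this assay, chloro and methoxy at this position, para to a large group, stand level, with a 1.1-fold lower number from compound 3 to compound 4 (0.05 log units; within the scatter), so this direct exchange on an aromatic carbon leaves the number within the scatter. The 4-chlorophenyl group also stands level with the 3-fluorophenyl group, with a 1.3-fold lower number from compound 2 to compound 4 (0.12 log units; within the scatter), which adds a third aryl group to this level range. A single chloro does not match the result of 2,4,6-trichlorophenyl, although compound 1 stands at a limit, so an at least 5.5-fold lower number from compound 1 to compound 4 (0.74 log units; beyond the scatter) gives only a bound: the limit of > 100000 nM in this assay, at which 1 of the 4 values shown sits.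

Which of the additional chloro groups in 2,4,6-trichlorophenyl accounts for that step remains open. So does whether an amine or a carboxylic acid at this position, or a longer chain on the shared core, would move the number beyond the scatter.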